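The source may report more compounds than this note shows. Statements on the series, on what has been measured and on what is new or still open speak of the compounds shown alone.

Three compounds sharing a pyridine-centred core were tested in an assay on isolated protein for inhibition of DNA topoisomerase 1 (Homo sapiens), with a stated time of 30 min, tested at 20 uM; a lower number here means a weaker effect, a higher number a stronger effect of the compound at the concentration tested. Compound 1, `Oc1ccccc1-c1cc(-c2cccs2)cc(-c2ccccc2O)n1`, gives 0.2% in this assay. Compound 2, `Oc1cccc(-c2cc(-c3cccs3)cc(-c3ccccc3O)n2)c1`, gives 1.5%, and compound 3, `Oc1cccc(-c2cc(-c3ccco3)cc(-c3ccccc3O)n2)c1`, gives 0%. Going from compound 1 to compound 2 the change is 3-hydroxyphenyl in place of 2-hydroxyphenyl on an aromatic carbon, and the read-out moves by a number 1.3 percentage points higher from compound 1 to compound 2 (within the scatter). Going from compound 2 to compound 3, furan-2-yl replaces thiophen-2-yl on an aromatic carbon, and the read-out moves by a number 1.5 percentage points lower from compound 2 to compound 3 (within the scatter). None of these three compounds therefore shows a read-out that can be told apart from the others in this assay.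

Compound 4, `Oc1cccc(-c2cc(-c3ccco3)cc(-c3cccc(O)c3)n2)c1`, has not yet been measured. It differs from compound 3 by 3-hydroxyphenyl in place of 2-hydroxyphenyl on an aromatic carbon. Among the compounds with values here, this is the same kind of change as the one from compound 1 to compound 2, but the surroundings differ: in compound 1 the changed position is meta to a 2-hydroxyphenyl group and meta to a thiophen-2-yl group, whereas in compound 3 it is meta to a 3-hydroxyphenyl group and meta to a furan-2-yl group. How the cores of compound 1 and compound 3 differ is not broken down here.

Because the earlier instance of this change gave a number 1.3 percentage points higher from compound 1 to compound 2 (within the scatter), the step from compound 3 to compound 4 is expected to be a number 1 percentage points higher from compound 3 to compound 4 (within the scatter). Compound 4 is thus estimated to give 1% in this assay, with a likely range from 0% to 5%.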

Compound 4, a percentage reported as inhibition, at one concentration (the size of the read-out at that concentration, not a potency): 0%
For compound 4 the middle estimate is 1 percentage points above the measured one; measured number inside the range.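

In this assay, placing 3-hydroxyphenyl where 2-hydroxyphenyl stood on the core of compound 3 gives no change at the digits printed from compound 3 to compound 4 (within the scatter). Set beside the earlier use of the same swap, on the core of compound 1, the two results agree: the same change on two cores in this assay, a number 1.3 percentage points higher (within the scatter) from compound 1 to compound 2 and no change at the digits printed (within the scatter) from compound 3 to compound 4, 1.3 percentage points apart, within the scatter of two such steps This shows that, in these two cases, the swap left the read-out within the scatter whether the other groups on the core were thiophen-2-yl and 2-hydroxyphenyl or furan-2-yl and 3-hydroxyphenyl, but all four read-outs are small, so it does not show that the swap would be equally silent on a compound with a large read-out, where a real gain or loss would have room to appear.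

The compounds shown leave open whether any group on this core can raise the read-out clearly above the scatter, since only hydroxyphenyl, thiophen-2-yl and furan-2-yl groups appear here. On these data alone, a 4-hydroxyphenyl group, an amine or a carboxylic acid in place of the hydroxyl, or a longer chain on the core could test this, and it also remains open how the swap behaves on a compound whose read-out is clearly above those seen here.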